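A few compounds are considered here, and "the series" means these few. Any claim that something is new, unique, unknown or untested is made for them only; others in the source may bear on it.

Working notes on the series. Among the compounds with values here, in a functional assay on the whole organism for inhibition, with Rattus norvegicus as the target, at a dose of 30 mg/kg (a lower number here means less inhibition, a higher number more inhibition at the dose given (going by the name of the read-out)), compound 1 `CSc1ccccc1-c1nc2ncccc2o1` gives 21%, the second highest of the three numbers so far. Compound 2 `N#Cc1cccc(C#N)c1-c1nc2ncccc2o1` gives 19% in this assay, which lies within the scatter of compound 1, so no order between the two is read. Compound 3 `Fc1cccc(-c2nc3cccnc3o2)c1` gives 35% in this assay, a higher number than compound 1 by more than the scatter.

Compound 4 `c1ccc(-c2nc3ncccc3o2)cc1` has not been measured in this assay. It differs from compound 1 by hydrogen in place of methylsulfanyl on an aromatic carbon. Within the data shown here, no measured pair shows this change, so its size is not known from the data. A small rise toward the number of compound 3 is expected, but one that may stay within the scatter, with a number 5 percentage points higher from compound 1 to compound 4 (within the scatter) as the estimated step. Compound 4 is expected to give about 26% in this assay, with a range from 10% to 42%.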

Compound 4, a percentage reported as inhibition, in the whole organism at one dose (the size of the read-out at that dose, not a potency): 41%
Estimate against measurement, compound 4: 15 percentage points below; low and high end bracket the measured number.
By their numbers in this assay, from the lowest: compounds 2 and 1 (each within the scatter of the next); then compounds 3 and 4 (each within the scatter of the next).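

In this assay, within the data shown here, the change to hydrogen in place of methylsulfanyl on an aromatic carbon gives a number 20 percentage points higher from compound 1 to compound 4 (beyond the scatter) as the first direct reading at this position. For this pair, methylsulfanyl at this place is not required for inhibition at the dose given, and the compound with hydrogen there gives the higher number. Nothing available bears on the cause of this step.

This rests on a single pair. Going by these compounds, whether methoxy, an amine or a carboxylic acid at the same place would stay nearer compound 1 or compound 4 remains open.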